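The source may report more compounds than this note shows. Statements on the series, on what has been measured and on what is new or still open speak of the compounds shown alone.

Three compounds have been measured in a functional assay on LOX IMVI cells (Homo sapiens) for inhibition; on this read-out higher numbers stand for weaker inhibition of growth and lower numbers for stronger inhibition of growth:

Compound 1 `COc1cc(/C=C/C(=O)c2cccc(-n3cc(-c4ccccc4)[nH]c3=O)c2)ccc1O`: 1880 nM
Compound 2 `COc1cc(/C=C/C(=O)c2cccc(-n3cc(-c4ccccc4)[nH]c3=O)c2)cc(OC)c1OC`: 480 nM
Compound 3 `COc1ccc(-c2cn(-c3cccc(C(=O)/C=C/c4cc(OC)c(OC)c(OC)c4)c3)c(=O)[nH]2)cc1`: 720 nM

Compound 1 gives the highest of the three numbers, so it is the weakest inhibitor of growth in this set. Compound 3 sits lower by a gap beyond the scatter, and compound 2 lower still, also beyond the scatter; compound 2 and compound 3 differ from compound 1 on the other aromatic ring, where extra methoxy groups stand, so those gaps say nothing direct about the change at hand.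

Compound 4 `COc1cc(/C=C/C(=O)c2cccc(-n3cc(-c4ccc(Cl)cc4)[nH]c3=O)c2)ccc1O` differs from compound 1 by chloro in place of hydrogen on an aromatic carbon. Going by the values given here, the one measured single-site step, a 1.5-fold higher number from compound 2 to compound 3 (0.18 log units; within the scatter), also places a group on that same phenyl ring, and it left the number within the scatter. Nothing measured here shows what a chloro group at that place does, so the expectation rests on that single neighbouring step and on the common finding that one small substituent on a terminal ring seldom moves such a number far. Compound 4 is therefore expected to show a 1.2-fold lower number from compound 1 to compound 4 (0.07 log units; within the scatter), that is, no step beyond the scatter. Compound 4 is estimated at 1600 nM, with a range from 600 nM to 4200 nM.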

Compound 4, concentration for 50% growth inhibition: 1630 nM
Beside the measured number, compound 4's estimate is 1.0-fold (0.01 log units) below it, and the stated range covers the measured number.
By their numbers in this assay, from the lowest: compounds 2 and 3 (each within the scatter of the next); then compounds 4 and 1 (each within the scatter of the next).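

In this assay, the step from phenyl to 4-chlorophenyl, with chloro in place of hydrogen para to a large group, gives a 1.2-fold lower number from compound 1 to compound 4 (0.06 log units; within the scatter), so the two numbers cannot be told apart. Until now, the only single-site step at this place was the methoxy step, a 1.5-fold higher number from compound 2 to compound 3 (0.18 log units; within the scatter), made in compounds with three methoxy groups on the other aromatic ring; this second step, made in compounds with a hydroxy and a methoxy group on that ring, also stays within the scatter, so in both pairs shown a small added group at this place gives no readable shift. Nothing available here explains why these numbers lie so close together.

On these data alone, these two steps cover only methoxy and chloro at this one place, so it remains open whether an amine, a carboxylic acid or a longer chain there would move the number beyond the scatter. As far as these compounds go, it is also open whether chloro would behave in the same way at another place on this ring, or in a compound with three methoxy groups on the other aromatic ring.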